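From methoxy to hydroxy on an aromatic ring

The source may hold more compounds than are shown below. What is called first, only, known or untested is meant among the compounds shown, and "the series" means these compounds.

Two related compounds have been tested in a functional assay on SW480 cells (Homo sapiens) for antiproliferative activity, read by sulforhodamine B assay, with a stated time of 48 h (a higher number here means a weaker inhibitor, a lower number a stronger inhibitor), so far. Compound 1 (`COc1ccc(C(=O)/C=C/c2ccccc2-c2ccc(F)cc2)cc1`) comes in at 8400 nM and compound 2 (`COc1ccc(C(=O)/C=C/c2ccccc2-c2ccc(F)cc2)cc1OC`) at 8300 nM on this measure. These two numbers lie within the usual scatter of each other, so compound 2 stands level with compound 1 and neither can be ranked ahead.

Compound 3 (`COc1cc(C(=O)/C=C/c2ccccc2-c2ccc(F)cc2)ccc1O`) has not been measured yet. Its change from compound 2 (hydrogen in place of methyl on an oxygen on an aromatic ring) is hydrogen in place of methyl on an oxygen on an aromatic ring, or methoxy to hydroxy. Among the compounds with values here, the only measured step available for comparison is methoxy in place of hydrogen on an aromatic carbon (a 1.0-fold lower number from compound 1 to compound 2 (0.01 log units; within the scatter)), and it stayed within the scatter. Within the data shown here, that is a different change, and no measured pair shows a hydroxy, so it guides the expectation only loosely. No step beyond the scatter is therefore expected in this assay in either direction. The estimated step is a 1.2-fold lower number from compound 2 to compound 3 (0.07 log units; within the scatter) and it would be a small one. The estimate for compound 3 is 7000 nM with 3000 nM to 16000 nM as the expected range.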

Compound 3, half-maximal inhibitory concentration: 4200 nM
Estimate against measurement, compound 3: 1.7-fold (0.22 log units) above, within the range that was stated.
By their numbers in this assay, from the lowest: compounds 3, 2 and 1 (each within the scatter of the next).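

Within the data shown here, compound 3 is the only compound here that carries a hydroxy group, so it gives the first reading of a free hydroxy on this ring in this assay. Putting hydrogen in place of methyl on this oxygen gives a 2.0-fold lower number from compound 2 to compound 3 (0.30 log units; within the scatter), a step at the very edge of the usual scatter but still inside it, so compound 3 cannot be ranked ahead of compound 2. Together with the earlier step, a 1.0-fold lower number from compound 1 to compound 2 (0.01 log units; within the scatter), this shows that neither change on this part of the ring has yet produced a readable difference, and nothing available explains the size of either step.

The compounds shown leave open whether a larger change on this oxygen, such as a longer chain like propoxy, or an amine or a carboxylic acid on the same ring carbon, would move the number beyond the scatter. They also leave open whether the same swap from methoxy to hydroxy would read the same way at the methoxy group that compound 1 carries.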